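This account rests on a few compounds, and the source may have more. Where it says the series, first, only, none or still open, it means among the compounds named here.

Measured compounds:
Compound 1, `Oc1ccc(-c2cc(-c3ccc(O)cc3)nc(-c3ccc(O)cc3)c2)cc1`, with 790 nM
Compound 2, `Oc1ccc(-c2cc(-c3cccc(O)c3)cc(-c3cccc(O)c3)n2)cc1`, with 1560 nM

Both numbers come from an ADME assay on HEK293 cells (Homo sapiens) for cytotoxicity, read by CCK-8 assay, with a stated time of 4 days; a lower number here means a stronger inhibitor, a higher number a weaker inhibitor. Compound 2 and compound 1 share a core and differ only in which hydroxyphenyl groups hang from it; their two values lie within the usual scatter of each other, so neither compound can be called the stronger or the weaker on this evidence. Within the data shown here, no single-change step between measured compounds is available.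

Compound 3, `Oc1ccc(-c2cc(-c3cccc(O)c3)cc(-c3ccc(O)cc3)n2)cc1`, has not been measured in this assay. It differs from compound 2 in one place: 4-hydroxyphenyl in place of 3-hydroxyphenyl on an aromatic carbon. Compound 3 thus sits between compound 2 and compound 1 in the count of 4-hydroxyphenyl groups on the core. Since the gap between compound 2 and compound 1 is itself within the scatter, the expected step from compound 2 to compound 3 is small, toward compound 1, and not clearly beyond the scatter: a 1.4-fold lower number from compound 2 to compound 3 (0.15 log units; within the scatter). The estimate for compound 3 in this assay is 1100 nM, with a range from 550 nM to 2200 nM.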

Compound 3, half-maximal inhibitory concentration: > 50000 nM
Compound 3: a limit, no number; the forecaster's own chance of this, stated with the estimate: 5%; at least 45-fold (1.65 log units) between middle value and limit.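

In this assay, compound 3 carries a limit and not a number, > 50000 nM. Placing 4-hydroxyphenyl in place of 3-hydroxyphenyl on the aromatic carbon next to the ring nitrogen gives an at least 32-fold higher number from compound 2 to compound 3 (1.50 log units; beyond the scatter), and placing 3-hydroxyphenyl in place of 4-hydroxyphenyl on an aromatic carbon gives an at least 63-fold higher number from compound 1 to compound 3 (1.80 log units; beyond the scatter). Compound 3 thus stands far from both of its single-change neighbours, although the groups exchanged have the same atoms and the same counts, so the mere location of the hydroxyl on one phenyl group can matter greatly on this core, which the earlier compounds gave no sign of, and the true size of both steps remains bounded by a limit: the limit of > 50000 nM in this assay, at which 1 of the 3 values shown sits.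

The compounds shown leave open whether the jump belongs to this one position or to the particular combination of 3-hydroxyphenyl and 4-hydroxyphenyl groups found in compound 3. They also leave open whether a methoxy group or an amine in place of the hydroxyl on these phenyl groups would keep the number of compound 3 or bring it back toward that of compound 2.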